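This account rests on a few compounds, and the source may have more. Where it says the series, first, only, none or still open, it means among the compounds named here.

Measured so far in a functional assay on a cell-free system (Platelet, plasma, Homo sapiens) for inhibition; a lower number here means a stronger inhibitor, a higher number a weaker inhibitor:

- compound 1 `Cc1ccc(N(CCN2CCC(OCC(=O)O)CC2)C(=O)c2cccc(F)c2)cc1` gives 160 nM
- compound 2 `COc1cccc(C(=O)N(CCN2CCC(OCC(=O)O)CC2)c2ccc(C)cc2)c1` gives 32 nM
- compound 3 `Cc1ccc(N(CCN2CCC(OCC(=O)O)CC2)C(=O)c2cccc(C(F)(F)F)c2)cc1` gives 20000 nM

Compound 3 has the highest number of the three, which makes it the weakest inhibitor of this small set. The next compound, compound 4 `COc1cccc(C(=O)N(CCN2CCC(OCC(=O)O)CC2)c2ccc(C)cc2)c1OC`, has not yet been measured. It has 2,3-dimethoxyphenyl in place of 3-(trifluoromethyl)phenyl on a carbonyl carbon.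

For the measured compounds named here, three measured steps bear on this swap. The closest is a 630-fold higher number from compound 2 to compound 3 (2.80 log units; beyond the scatter), which shows how much was lost when trifluoromethyl took the place of methoxy. Compound 4 removes that trifluoromethyl and carries methoxy groups instead. The step of a 130-fold higher number from compound 1 to compound 3 (2.10 log units; beyond the scatter) shows the same kind of loss against fluoro, while a 5.0-fold lower number from compound 1 to compound 2 (0.70 log units; beyond the scatter) favours methoxy, though more modestly. Together they point to a large move toward a lower number. Going by the values given here, no measured compound carries two methoxy groups, however, so the contribution of the second one is unknown and the range must stay wide.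

An estimated step of a 200-fold lower number from compound 3 to compound 4 (2.30 log units; beyond the scatter) is expected in this assay. For compound 4 the expected value is 100 nM, with an estimated range from 12 nM to 1500 nM.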

Compound 4, half-maximal inhibitory concentration: 1600 nM
Beside the measured number, compound 4's estimate is 16-fold (1.20 log units) below it; the whole stated range lies below it.
By their numbers in this assay, from the lowest: compound 2; then compound 1; then compound 4; then compound 3.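

In this assay, the clearest new lesson comes from adding a second methoxy: a 50-fold higher number from compound 2 to compound 4 (1.70 log units; beyond the scatter) makes this a clear loss, so more methoxy on this ring does not mean a stronger inhibitor. Replacing 3-(trifluoromethyl)phenyl with 2,3-dimethoxyphenyl still helps, with a 13-fold lower number from compound 3 to compound 4 (1.10 log units; beyond the scatter) as the measured gain, but it recovers only part of what separates compound 3 from compound 2. The comparison with 3-fluorophenyl, a 10-fold higher number from compound 1 to compound 4 (1.00 log units; beyond the scatter) as its step, adds that a methoxy-bearing ring on this carbonyl carbon does not always beat the fluoro one, since compound 2 has the lower number than compound 1 while compound 4 has the higher; no measurement shown here explains the cost of the second methoxy.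

Still open, from the compounds shown here alone, is whether the loss comes from the added methoxy alone or from the two methoxy groups acting together. It is also unknown how a smaller or larger group, such as a chloro, a hydroxyl or an ethoxy, would fare on the aromatic carbon that carries the added methoxy.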